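This account rests on a few compounds, and the source may have more. Where it says the series, first, only, none or still open, it means among the compounds named here.

Working notes on the series, read in a functional assay on ACHN cells (Homo sapiens) for inhibition, read by sulforhodamine B assay, with a stated time of 48 h; a lower number here means that less compound is tolerated, a higher number that more compound is tolerated. Compound 1 (`O=C(Nc1cccc(-n2cc(-c3ccncc3)c(-c3ccc(Cl)c(O)c3)n2)c1)Nc1cccc(C(F)(F)F)c1`) gives > 32500 nM, which is a limit and not a number. Within the data shown here, no measured step connects it with compound 2 (`COc1cc(-c2nn(-c3cccc(NC(=O)c4cccc(C(F)(F)F)c4)c3)cc2-c2ccncc2)ccc1Cl`), so its standing rests on that limit alone. Compound 3 (`COc1cc(-c2nn(-c3cccc(NC(=O)Nc4cccc(C(F)(F)F)c4)c3)cc2-c2ccncc2)ccc1Cl`) keeps the core of compound 1 and differs by methyl in place of hydrogen on an oxygen on an aromatic ring, turning 4-chloro-3-hydroxyphenyl into 4-chloro-3-methoxyphenyl. Compound 2 carries that same 4-chloro-3-methoxyphenyl and gives > 50000 nM, again a limit and not a number. On that basis no change beyond the scatter is expected, and the estimated step that the limit leaves unreadable from compound 1 to compound 3 stays small. For compound 3 the estimated value is 40000 nM, with an expected range of 12000 nM to 100000 nM.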

Compound 3, concentration lethal to 50% of the cells: > 50000 nM
Compound 3: only a limit was reported; the forecaster's own chance of this, stated with the estimate: 65%; at least 1.2-fold (0.09 log units) between middle value and limit.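

Compound 1, compound 2 and compound 3 are all reported only as limits, so neither step into compound 3 can be read. The compounds shown leave open what number each would give, and whether replacing hydroxy with methoxy changes the value at all.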